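This account rests on a few compounds, and the source may have more. Where it says the series, first, only, none or still open, it means among the compounds named here.

Measured compounds, with their readings in a functional assay on A549 cells (Homo sapiens), read by MTT assay, with a stated time of 72 h; on this read-out lower numbers stand for stronger inhibition and higher numbers for weaker inhibition:
compound 1, `CNc1ncnc2c1c(I)cn2[C@@H]1O[C@H](CO)[C@@H](O)[C@H]1O`, gives > 100000 nM, which is a limit of the assay and not a number;
compound 2, `COc1ncnc2c1c(I)cn2[C@@H]1O[C@H](CO)[C@@H](O)[C@H]1O`, gives > 20000 nM, likewise a limit of the assay;
compound 3, `COc1ncnc2c1c(-c1cc3ccccc3o1)cn2[C@@H]1O[C@H](CO)[C@@H](O)[C@H]1O`, gives 17700 nM.

Compound 3 is thus the only one of the three with a number in this assay. From compound 2 to compound 3 the change is 1-benzofuran-2-yl in place of iodo on an aromatic carbon, and the step is an at least 1.1-fold lower number from compound 2 to compound 3 (0.05 log units; that floor lies within the scatter). From compound 2 to compound 1 the change is methylamino in place of methoxy on an aromatic carbon, and the step there is a step that the two limits leave unreadable from compound 2 to compound 1; the values of compound 1 and compound 2 stand at the limit of > 100000 nM in this assay, at which 1 of the 3 values shown sits, and (the limit of > 20000 nM in this assay, at which 1 of the 3 values shown sits), so no direction or size can be read from that pair.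

Compound 4, `CNc1ncnc2c1c(-c1cc3ccccc3o1)cn2[C@@H]1O[C@H](CO)[C@@H](O)[C@H]1O`, has not been measured in this assay. It differs from compound 3 by methylamino in place of methoxy on an aromatic carbon, the same change as that from compound 2 to compound 1, made on the same place of the core; the two cores differ as described for compound 2 and compound 3 above. Since the earlier step of this kind is unreadable, the expectation for compound 4 rests mainly on the number for compound 3, 17700 nM, with wide uncertainty. The step from compound 3 to compound 4 is expected to be a 1.2-fold higher number from compound 3 to compound 4 (0.09 log units; within the scatter). Compound 4 is therefore estimated to give about 22000 nM, with a likely range from 5000 nM to 100000 nM.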

Compound 4, half-maximal inhibitory concentration: > 20000 nM
Compound 4 ended at the assay's limit; the forecaster's own chance of this, stated with the estimate: 35%; the middle value does not contradict the limit.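

In this assay compound 4 gives > 20000 nM, which is a limit of the assay and not a number. Carrying methylamino in place of methoxy on an aromatic carbon onto the core of compound 3 gives an at least 1.1-fold higher number from compound 3 to compound 4 (0.05 log units; that floor lies within the scatter), so the reading shows only that compound 4 did not yield a number in the tested range and gives neither the true size of the step nor evidence of a real change. The same change on the core of compound 2 and the step between compound 1 and compound 4 cannot be read, so the account cannot say whether the change behaves alike on the two cores, and in each of those pairs one compound stands at the shared limit: the limit of > 20000 nM in this assay, at which 2 of the 4 values shown sit.

The compounds shown leave open whether a dimethylamino group, a longer chain such as ethoxy or a plain methyl group in the place of methoxy would give a readable number on either core. For the compounds shown here, they also leave open how a phenyl ring, a carboxylic acid or a primary amine in the place of 1-benzofuran-2-yl would read in this assay, since compound 3 alone carries a number so far.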